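The compounds below may be only part of what the source reports. "The series", "measured", "known", "first", "only" and "open" are said of these compounds alone.

Working notes on the series. The shared core is seen in compound 1 `O=[N+]([O-])c1cn2c(n1)OC[C@@H](OCc1ccc(-c3ccc(OC(F)(F)F)cc3)cc1Cl)C2`, which carries a biaryl ether tail. In an ADME assay on Vero cells (Chlorocebus sabaeus) for cytotoxicity, with a stated time of 72 h (a lower number here means a stronger inhibitor, a higher number a weaker inhibitor), compound 1 gives > 128000 nM, a limit of the assay and not a number. Compound 2 `O=[N+]([O-])c1cn2c(n1)OCC(COc1ccc(OC(F)(F)F)cc1)C2` carries a simpler aryl ether tail at a ring carbon drawn without configuration. In this assay compound 2 gives > 128000 nM, again a limit rather than a number. On the numbers shown compound 2 stands at the assay limit (the limit of > 128000 nM in this assay, at which 2 of the 2 values shown sit), so no order among the measured compounds can be read. Compound 3 `O=[N+]([O-])c1cn2c(n1)OC[C@H](COc1ccc(OC(F)(F)F)cc1)C2` differs from compound 2 in one respect: the two compounds have the same atoms and bonds; at least one stereo element is drawn with a configuration in one of them and without one in the other: 1 of 1 stereo elements differ; a stereocentre at a saturated ring carbon is drawn without a configuration in compound 2 and S in compound 3. Among the compounds with values here, no measured step between compounds exists in the set. With both values shown sitting at the limit, the step that the limit leaves unreadable from compound 2 to compound 3 is expected to lie within the scatter, with no change in either direction. For compound 3 in this assay the estimate is 150000 nM, with a range from 60000 nM to 400000 nM.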

Compound 3, half-maximal inhibitory concentration: > 128000 nM
Compound 3: only a limit was reported; the forecaster's own chance of this, stated with the estimate: 85%; the middle value is on the limit's open side.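

The step from compound 2 to compound 3 in this assay cannot be read, because both values are limits and not numbers: the limit of > 128000 nM in this assay, at which 3 of the 3 values shown sit.

The compounds shown leave open whether the S configuration drawn in compound 3 matters in this assay, and what true values lie beyond the limit.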